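Removing a fluorine from the least cytotoxic member

The source may hold more compounds than are shown below. What is called first, only, known or untested is meant among the compounds shown, and "the series" means these compounds.

Of the compounds shown here, three of a shared core have been tested in a functional assay on DLD-1 cells (Homo sapiens) for cytotoxicity, read by colorimetric assay and MTT assay, with a stated time of 3 days, tested at 1 uM; on this read-out lower numbers stand for a stronger effect and higher numbers for a weaker effect at the one concentration tested. Compound 1 `O=C1COc2ccc(-c3[nH]c(-c4ccc(F)cc4)nc3-c3ccccc3)cc2N1` gives 94.8%, the highest of the three numbers, which here means the weakest effect. Compound 2 `O=C1COc2ccc(-c3nn(-c4ccc(Cl)cc4)cc3-c3ccccc3)cc2N1` gives 61.9%, and compound 3 `O=C1COc2ccc(-c3nn(-c4ccccc4)cc3-c3ccccc3)cc2N1` gives 77%; both stand beyond the scatter below compound 1.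

The new compound 4 `O=C1COc2ccc(-c3[nH]c(-c4ccccc4)nc3-c3ccccc3)cc2N1` differs from compound 1 by hydrogen in place of fluoro on an aromatic carbon.

Within the data shown here, only one measured step bears on this: a number 15.1 percentage points higher from compound 2 to compound 3 (beyond the scatter). That step is also a halogen on an aromatic carbon giving way to hydrogen, though the halogen there is chloro and the surrounding ring of the core differs. It raised the number, so the loss of the fluoro in compound 4 is expected to push in the same direction, though a read-out already near full cell survival cannot rise much further. Compound 4 is therefore expected to show a step of a number 2.2 percentage points higher from compound 1 to compound 4 (within the scatter), small and likely within the scatter. The estimate for compound 4 in this assay is 97%, with a range from 87% to 106%.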

Compound 4, a percentage reported as activity, at one concentration (the size of the read-out at that concentration, not a potency): 98.2%
Compound 4: middle estimate off by 1.2 percentage points, on the low side, and the stated range covers the measured number.
By their numbers in this assay, from the lowest: compound 2; then compound 3; then compounds 1 and 4 (each within the scatter of the next).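

In this assay, the change from 4-fluorophenyl to phenyl gives a number 3.4 percentage points higher from compound 1 to compound 4 (within the scatter) and so leaves no readable mark at this place on the core of compound 1, at the one concentration tested. Among these compounds, this adds a second case to the only earlier exchange of a halogen for hydrogen, a number 15.1 percentage points higher from compound 2 to compound 3 (beyond the scatter) on a different core, which did move the number beyond the scatter. The two steps differ in both the halogen and the core, so these compounds cannot show which of the two differences separates the outcomes, and no supporting measurement is available to explain the contrast.

The compounds shown leave open whether any group at this place, on the aromatic ring and para to a large group, can lower the number on this core, for example a chloro, a methoxy group, an amine or a carboxylic acid. They also leave open whether the fluoro would matter at another concentration, since a single concentration gives the size of the read-out and not a potency.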